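Swapping the benzyl substituent from bromine to methoxy

The source may hold more compounds than are shown below. What is called first, only, known or untested is meant among the compounds shown, and "the series" means these compounds.

Measured so far:
Compound 1 `COC(=O)/C=C/c1cccc(N(Cc2ccc(-c3cccc(OC)c3)cc2)C(=O)NC(C)C)c1` in an assay on isolated protein with Bile acid receptor (Homo sapiens) as the target; on this read-out higher numbers stand for an effect only at larger amounts of compound and lower numbers for an effect already at smaller amounts: compound 1 gives 1370 nM.
Compound 2 `CCOC/C=C/c1cccc(N(Cc2ccc(/C=C/C(=O)OC(C)(C)C)cc2)C(=O)C2CCCCC2)c1`: compound 2 gives 220 nM.
Compound 3 `COC(=O)/C=C/c1cccc(N(Cc2ccccc2Br)C(=O)C2CCCCC2)c1`: compound 3 gives > 1000 nM.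

The value for compound 3 is only a limit of this assay, not a number, as noted in the limit of > 1000 nM in this assay, at which 1 of the 3 values shown sits, and it sits at the weak end of the three results shown. Compound 4 `COC(=O)/C=C/c1cccc(N(Cc2cccc(OC)c2)C(=O)C2CCCCC2)c1` differs from compound 3 in one place: 3-methoxyphenyl in place of 2-bromophenyl on a saturated chain carbon bound to an amide-type nitrogen. Going by the values given here, since no pair of measured compounds differs in exactly this way, no measured step guides the expectation. The step from compound 3 to compound 4 is expected to be a step that the limit leaves unreadable from compound 3 to compound 4, perhaps modest and in either direction, with a fair chance that compound 4 again yields only a limit. Compound 4 is therefore estimated at 1500 nM, within the range 300 nM to 6000 nM.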

Compound 4, half-maximal effective concentration: > 1000 nM
Compound 4: only a limit was reported; the forecaster's own chance of this, stated with the estimate: 45%; the middle value does not contradict the limit.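

Compound 3 and compound 4 both give only a limit of the assay, not a number, so no step between them can be read: the limit of > 1000 nM in this assay, at which 2 of the 4 values shown sit.

The compounds shown leave open whether 3-methoxyphenyl in place of 2-bromophenyl changes the result at all.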